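Replacing an aromatic tail with a short alkyne

This account rests on a few compounds, and the source may have more. Where it says the series, first, only, none or still open, it means among the compounds named here.

Compound 1 `O=c1[nH]/c(=N\OCCCc2cccc(F)c2)ccn1[C@@H]1O[C@H](COP(=O)(O)OP(=O)(O)OP(=O)(O)O)[C@@H](O)[C@H]1O`: 100 nM
Compound 2 `O=c1[nH]/c(=N\OCCCc2ccc(I)cc2)ccn1[C@@H]1O[C@H](COP(=O)(O)OP(=O)(O)OP(=O)(O)O)[C@@H](O)[C@H]1O`: 91 nM
Compound 3 `COc1ccc(CCCO/N=c2/ccn([C@@H]3O[C@H](COP(=O)(O)OP(=O)(O)OP(=O)(O)O)[C@@H](O)[C@H]3O)c(=O)[nH]2)cc1`: 23 nM

In a functional assay on 1321-N1 cells for agonist activity at P2Y purinoceptor 4 (Homo sapiens), read by scintillation counting and inositol phosphate accumulation (on this read-out higher numbers stand for an effect only at larger amounts of compound and lower numbers for an effect already at smaller amounts), compound 3 gives the lowest number of the three, and its steps from compound 1 and compound 2 are both beyond the scatter, so it is the most potent compound measured here. Compound 4 `C#CCCCO/N=c1/ccn([C@@H]2O[C@H](COP(=O)(O)OP(=O)(O)OP(=O)(O)O)[C@@H](O)[C@H]2O)c(=O)[nH]1` differs from it by ethynyl in place of 4-methoxyphenyl on a saturated chain carbon, three bonds along the chain from an oxygen on an unsaturated carbon. Among the measured compounds shown here, no measured step removes the aromatic ring entirely; the nearest guides are a 4.3-fold lower number from compound 1 to compound 3 (0.64 log units; beyond the scatter) and a 4.0-fold lower number from compound 2 to compound 3 (0.60 log units; beyond the scatter), where only the group on the ring changed and the number moved modestly. Taking away the whole ring is a larger change, and a move toward higher numbers seems more likely than a further gain. Compound 4 is therefore expected to give about 150 nM in this assay, between 40 nM and 600 nM, which would mean a 6.5-fold higher number from compound 3 to compound 4 (0.81 log units; beyond the scatter).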

Compound 4, half-maximal effective concentration: 410 nM
Compound 4: the middle estimate sits 2.7-fold (0.44 log units) below what was measured; measured number inside the range.
By their numbers in this assay, from the lowest: compound 3; then compounds 2 and 1 (each within the scatter of the next); then compound 4.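

Taking away the ring altogether moves the result much further than changing a group on it did: in this assay the step is an 18-fold higher number from compound 3 to compound 4 (1.25 log units; beyond the scatter), a large one. The same replacement also gives a 4.5-fold higher number from compound 2 to compound 4 (0.65 log units; beyond the scatter) and a 4.1-fold higher number from compound 1 to compound 4 (0.61 log units; beyond the scatter), so all three aromatic tails give lower numbers than the ethynyl tail, whichever group their ring carries. No supporting measurement explains this difference. Still open, as far as these compounds go, is whether the alkyne itself matters, since a plain pentyl chain could separate the loss of the ring from the presence of the triple bond. An amine at the chain end, or an unsubstituted phenyl ring, would test this position further.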